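The compounds below may be only part of what the source reports. "The series", "measured", "known", "first", "only" and "open" are said of these compounds alone.

Measured so far, in an assay on isolated protein for displacement of a labelled ligand from melanin-concentrating hormone receptor 1 (Homo sapiens); on this read-out lower numbers stand for stronger inhibition and higher numbers for weaker inhibition:

compound 1, `O=C(CCc1ccc(C(F)(F)F)cc1)Nc1ccc2nc(N3CCC(c4ccccc4)C3)ccc2c1` — 25 nM
compound 2, `O=C(CCCCCCCCCCCCc1ccc(C(F)(F)F)cc1)Nc1ccc2nc([N+]34CCC(CC3)CC4)ccc2c1` — 5 nM
compound 3, `CCCc1cc(N(C)C)c2cc(NC(=O)CCc3ccc(C(F)(F)F)cc3)ccc2n1` — 12 nM

All three share a core carrying an amide arm that ends in a trifluoromethyl-bearing phenyl ring; they differ in the amine group on the core and, for compound 2, in the length of that arm. On this read-out compound 1 has the highest of the three numbers, so it is the weakest binder shown. Compound 3 is nearest to it, with a gap that lies beyond the usual scatter, and compound 2 is furthest, again beyond the scatter.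

Compound 4, `O=C(CCc1ccc(C(F)(F)F)cc1)Nc1ccc2nc(N3CCCCCC3)ccc2c1`, has not yet been measured in this assay. It differs from compound 1 in one place: azepan-1-yl in place of 3-phenylpyrrolidin-1-yl on an aromatic carbon. The phenyl-bearing ring leaves and a plain seven-membered ring enters, at the same position on the core.

Among the compounds with values here, no measured pair here mirrors this exact change, so the step can only be judged loosely. Compounds 2 and 3 show that quite different amine groups at this position still give low numbers, which suggests the core and the amide arm carry much of the binding. The expected step from compound 1 to compound 4 is therefore a 1.2-fold higher number from compound 1 to compound 4 (0.08 log units; within the scatter), that is, no change beyond the scatter, with a slight lean toward a higher number. Compound 4 is estimated at 30 nM in this assay, with a range from 8 nM to 120 nM.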

Compound 4, half-maximal inhibitory concentration: 36 nM
Compound 4: middle estimate off by 1.2-fold (0.08 log units), on the low side, within the range that was stated.
By their numbers in this assay, from the lowest: compound 2; then compound 3; then compounds 1 and 4 (each within the scatter of the next).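

Within the data shown here, replacing 3-phenylpyrrolidin-1-yl with azepan-1-yl gives in this assay a step of a 1.4-fold higher number from compound 1 to compound 4 (0.16 log units; within the scatter) and is the first comparison here in which only the group at this position changes. The group that leaves has 11 heavy atoms and a six-membered aromatic ring, while the group that enters has 7 heavy atoms and no aromatic ring, yet this pair shows no difference that stands clear of the usual variation between repeat measurements. No supporting data are available to explain why the two compounds read alike.

This one pair changes the ring size and removes the phenyl ring together, so the contribution of each cannot be read separately, and a plain pyrrolidin-1-yl at the same place would be needed to tell them apart. On these data alone, it also remains open whether a ring with a second hetero atom, such as morpholine or piperazine, or a seven-membered ring carrying a carboxylic acid, would keep the number in the same range.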